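A few compounds are considered here, and "the series" means these few. Any claim that something is new, unique, unknown or untested is made for them only; others in the source may bear on it.

Measured so far:
- compound 1 `CC1=CCC2C(CC[C@@]2(C)O)C(C)(C)C1CC[C@@H]1[C@@]2(C)CC[C@@H](O)C(C)(C)O[C@@H]2CC[C@]1(C)O`, which reaches only the assay limit of > 50000 nM.
- compound 2 `CC1=CC[C@H]2[C@H](CC[C@]2(C)O)C(C)(C)[C@@H]1CC[C@H]1[C@]2(C)CC[C@H](OC(=O)NS(=O)(=O)c3ccc(C)cc3)C(C)(C)O[C@H]2CC[C@@]1(C)O`, giving 47100 nM.
- compound 3 `CC1=CC[C@H]2[C@H](CC[C@]2(C)O)C(C)(C)[C@@H]1CC[C@H]1[C@]2(C)CC/C(=N/O)C(C)(C)O[C@H]2CC[C@@]1(C)O`, giving 42700 nM.

All three share one steroid-like core and were tested in a functional assay on MDA-MB-231 cells (Homo sapiens) for antiproliferative activity, read by MTT assay, with a stated time of 72 h; a higher number here means a weaker inhibitor, a lower number a stronger inhibitor. Compound 1 reaches only a limit there, so it contributes no number of its own. Compound 2 and compound 3 give numbers that sit within the usual scatter of each other, so neither can be called the stronger of the two. The one further observation to hand is the limit of > 50000 nM in this assay, at which 1 of the 3 values shown sits, which simply marks how far the assay can see. Among the compounds with values here, no step between two measured compounds is available, so nothing here tells how much a change at the carbonyl-bearing position moves the read-out.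

Compound 4 `CC1=CC[C@H]2[C@H](CC[C@]2(C)O)C(C)(C)[C@@H]1CC[C@H]1[C@]2(C)CC[C@H](OC(=O)c3ccco3)C(C)(C)O[C@H]2CC[C@@]1(C)O` differs from compound 2 in one place: furan-2-yl in place of ((4-methylphenyl)sulfonyl)amino on a carbonyl carbon. With every measured compound sitting at or near the top of the assay's range, the expectation for compound 4 is a number of much the same size as that of compound 2, and the step of a 1.2-fold lower number from compound 2 to compound 4 (0.07 log units; within the scatter) is expected to stay within the scatter. For compound 4 the estimate in this assay is therefore 40000 nM, expected to lie between 12000 nM and 80000 nM.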

Compound 4, half-maximal inhibitory concentration: 14000 nM
Beside the measured number, compound 4's estimate is 2.9-fold (0.46 log units) above it; measured number inside the range.
By their numbers in this assay, from the lowest: compound 4; then compounds 3 and 2 (each within the scatter of the next). At a limit, above all of these: compound 1.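

Within the data shown here, this is the first step between two measured compounds, and it shows that the group on this carbonyl carbon can move the read-out in this assay: furan-2-yl in place of ((4-methylphenyl)sulfonyl)amino gives a 3.4-fold lower number from compound 2 to compound 4 (0.53 log units; beyond the scatter), a modest change but one that lies beyond the scatter. The swap alters several things at once, since the group that leaves carries a six-membered aromatic ring of carbon only and a hydrogen-bond donor, while the group that enters is a five-membered aromatic ring with 1 hetero atom and 0 hydrogen-bond donors, so this single pair cannot separate those differences. No measurement shown gives a reason for the step.

Still open, as far as these compounds go, is whether a plain phenyl ring on this carbonyl carbon would behave like furan-2-yl, which would help show whether the size of the ring or its oxygen atom goes with the change. Open too, from the compounds shown here alone, is how an amine, a carboxylic acid or a longer alkyl chain at this place would move the number in this assay, and whether any of them would take it further than compound 4 does.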